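The source may report more compounds than this note shows. Statements on the series, on what has been measured and on what is new or still open speak of the compounds shown alone.

Measured so far in an ADME assay on Huh-7 cells (Homo sapiens) for cytotoxicity, read by a luciferase reporter and WST assay, with a stated time of 3 days; on this read-out lower numbers stand for higher toxicity in this test and higher numbers for lower toxicity in this test:
- compound 1 `COC(=O)CNC(=O)c1c(NO)cc(-c2ccc(C)cc2)oc1=O` gives > 20000 nM, a limit of the test
- compound 2 `O=C(NCc1ccccc1)c1c(NO)cc(-c2ccccc2)oc1=O` gives > 20000 nM, a limit of the test

Compound 2 stands at the upper limit of this assay; its value is a limit and not a measured number. Compound 1 likewise sits at that limit, as the limit of > 20000 nM in this assay, at which 2 of the 2 values shown sit, records. Going by the values given here, no step between measured compounds is available, so the change described below has no measured counterpart.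

Compound 3 `Cc1ccc(-c2cc(NO)c(C(=O)NCc3ccccc3)c(=O)o2)cc1` differs from compound 2 by methyl in place of hydrogen on an aromatic carbon. The same 4-methylphenyl group is carried by compound 1, whose value is also a limit. From this the expectation for compound 3 is no shift beyond the scatter, with the result most likely again a limit, the expected step being a step that the limit leaves unreadable from compound 2 to compound 3. Compound 3 is estimated at 25000 nM, with a range of 12000 nM to 60000 nM.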

Compound 3, half-maximal cytotoxic concentration: > 20000 nM
Compound 3 gave a limit, no number; the forecaster's own chance of this, stated with the estimate: 85%; the middle value does not contradict the limit.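

No step among compound 1, compound 2 and compound 3 can be read in this assay, since all three rest at one limit: the limit of > 20000 nM in this assay, at which 3 of the 3 values shown sit.

The compounds shown leave open at what concentration any of the three becomes cytotoxic, and whether phenyl to 4-methylphenyl shifts that concentration at all.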